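Compound 2 Loses Its Chlorines

The source may report more compounds than this note shows. Statements on the series, on what has been measured and on what is new or still open speak of the compounds shown alone.

In a functional assay on B16 cells (Mus musculus) for inhibition (a lower number here means a stronger inhibitor, a higher number a weaker inhibitor), compound 2 `COc1cc(/C=C/C(=O)c2cccc(NC(=O)c3ccc(Cl)cc3Cl)c2)ccc1O` gives 12.8 ug/mL, the highest number of the three measured. Compound 1 `COc1cc(/C=C/C(=O)c2cccc(NC(=O)c3c(Cl)cccc3Cl)c2)ccc1O` gives 1.58 ug/mL, and compound 3 `COC(=O)C(=O)Nc1cccc(C(=O)/C=C/c2ccc(O)c(OC)c2)c1` gives 4.41 ug/mL. Compound 4 `COc1cc(/C=C/C(=O)c2cccc(NC(=O)c3ccccc3)c2)ccc1O` remains unmeasured and carries phenyl in place of 2,4-dichlorophenyl on a carbonyl carbon. Two measured steps at this same place bear on it: an 8.1-fold higher number from compound 1 to compound 2 (0.91 log units; beyond the scatter) and a 2.9-fold lower number from compound 2 to compound 3 (0.46 log units; beyond the scatter). Both are modest, and neither removes chlorine alone, so the evidence is indirect. With compound 2 at the top of the range, a modest move to a lower number is expected. The expected change is a 2.1-fold lower number from compound 2 to compound 4 (0.33 log units; beyond the scatter). Compound 4 is estimated at 6 ug/mL, with an expected range of 2 ug/mL to 16 ug/mL.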

Compound 4, half-maximal inhibitory concentration: 0.82 ug/mL
The estimate for compound 4 lay 7.3-fold (0.86 log units) above the measured number; the whole stated range lies above it.
By their numbers in this assay, from the lowest: compounds 4 and 1 (each within the scatter of the next); then compound 3; then compound 2.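

In this assay, going by these compounds alone, the bare phenyl gives the first direct reading of the chlorines on this ring, with a 16-fold lower number from compound 2 to compound 4 (1.19 log units; beyond the scatter) as the step. It also stands apart from the methoxycarbonyl group, with a 5.4-fold lower number from compound 3 to compound 4 (0.73 log units; beyond the scatter) as the step. The step of a 1.9-fold lower number from compound 1 to compound 4 (0.28 log units; within the scatter) does not separate phenyl from 2,6-dichlorophenyl, so among these compounds the penalty goes with 2,4-dichlorophenyl, and compound 1 shows that two chlorines do not always bring it. As far as these compounds go, how a single chlorine, an amine or a carboxylic acid on this phenyl would read remains open. Nothing available explains these differences.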